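Methoxy to tert-Butyl: What the Permeability Reading Should Show

A few compounds are considered here, and "the series" means these few. Any claim that something is new, unique, unknown or untested is made for them only; others in the source may bear on it.

Of the compounds shown here, three have been measured in an ADME assay for permeability, using PAMPA, with a stated time of 30 min, at pH 7.4; on this read-out lower numbers stand for lower permeability and higher numbers for higher permeability. Compound 1 `COc1ccc(Oc2ccc3c(NCCCNCc4cc(F)ccc4OC)ccnc3c2)cc1` gives 317 10^-6 cm/s. Compound 2 `COc1ccccc1Oc1ccc2c(NCCCNCc3ccco3)ccnc2c1` gives 317 10^-6 cm/s, and compound 3 `COc1ccc(Oc2ccc3c(NCCCNCc4cccc(OC)c4O)ccnc3c2)cc1` gives 317 10^-6 cm/s. Going by the values given here, compound 1 thus stands level with compounds 2 and 3, and the only single-point step among them, no change at the digits printed from compound 1 to compound 3 (within the scatter), concerns a different part of the molecule. The unmeasured compound 4 `COc1ccc(F)cc1CNCCCNc1ccnc2cc(Oc3ccc(C(C)(C)C)cc3)ccc12` differs from compound 1 by tert-butyl in place of methoxy on an aromatic carbon. Among the compounds with values here, no measured step touches the 4-methoxyphenoxy part, so nothing bears directly on this change; the sole guide is that all three measured compounds sit at one reading. Compound 4 is therefore expected to show no step beyond the scatter, no change at the digits printed from compound 1 to compound 4 (within the scatter). The estimate for compound 4 is 317 10^-6 cm/s, within 200 10^-6 cm/s to 500 10^-6 cm/s.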

Compound 4, apparent permeability: 317 10^-6 cm/s
The estimate for compound 4 equals the measured number at the digits printed, within the range that was stated.
By their numbers in this assay, from the lowest: compounds 1, 2, 3 and 4 (each within the scatter of the next).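

Read in this assay, tert-butyl in place of methoxy on an aromatic carbon gives no change at the digits printed from compound 1 to compound 4 (within the scatter), and this is the first reading that touches the 4-methoxyphenoxy part. At this position, a group of 2 heavy atoms with a hydrogen-bond acceptor gives way to one of 4 heavy atoms with none, and the reading stays level. Nothing at hand accounts for this result.

From the compounds shown here alone, all four compounds print one value, so it remains open whether any group here would shift the reading. A carboxylic acid or an amine on this aromatic carbon would put that question to a sharper test.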